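Chloro in Place of Fluoro: An Expected Potency Step

A few compounds are considered here, and "the series" means these few. Any claim that something is new, unique, unknown or untested is made for them only; others in the source may bear on it.

Three compounds were measured in a functional assay on A549 cells (Homo sapiens) for inhibition, read by MTT assay, with a stated time of 24 h; on this read-out lower numbers stand for stronger inhibition and higher numbers for weaker inhibition:
compound 1 `CC1(C)[C@H]2CC[C@]1(C)N(Cc1cn(-c3ccc(F)cc3)nn1)C(=O)C2` gives 230 nM
compound 2 `Cc1ccccc1-n1cc(CN2C(=O)C[C@@H]3CC[C@@]2(C)C3(C)C)nn1` gives 90 nM
compound 3 `CC1(C)[C@H]2CC[C@]1(C)N(Cc1cn(-c3cccc(Br)c3)nn1)C(=O)C2` gives 90 nM

Compound 1 carries the highest number of the three. Its two neighbours sit on the same side of it: a 2.6-fold lower number from compound 1 to compound 2 (0.41 log units; beyond the scatter) and a 2.6-fold lower number from compound 1 to compound 3 (0.41 log units; beyond the scatter), while no change at the digits printed from compound 2 to compound 3 (within the scatter). The unmeasured compound 4 `CC1(C)[C@H]2CC[C@]1(C)N(Cc1cn(-c3ccc(Cl)cc3)nn1)C(=O)C2` differs from compound 1 by chloro in place of fluoro on an aromatic carbon, para to a large group. Within the data shown here, no measured pair shares this change directly; the two steps from compound 1 alter both the group and where it sits on the phenyl ring, so they only show that moving away from 4-fluorophenyl has so far brought a modest decrease in the number. On that thin basis compound 4 is expected to land close to or somewhat under compound 1, with a 1.5-fold lower number from compound 1 to compound 4 (0.19 log units; within the scatter) as the estimated step. Compound 4 is therefore estimated at 150 nM, within a range of 70 nM to 350 nM, a step that may well stay within the scatter.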

Compound 4, half-maximal inhibitory concentration: 70 nM
Compound 4: middle estimate off by 2.1-fold (0.33 log units), on the high side; measured number inside the range.
By their numbers in this assay, from the lowest: compounds 4, 2 and 3 (each within the scatter of the next); then compound 1.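

Fluoro and chloro trade places on the same aromatic carbon, para to a large group, so this is the first step here in which the group changes while its place on the phenyl ring stays fixed. In this assay, among these compounds, that single exchange gives a 3.3-fold lower number from compound 1 to compound 4 (0.52 log units; beyond the scatter), which shows that the identity of the group at this position is enough by itself to move the number beyond the scatter, something the earlier steps, which altered group and place together, could not separate. The new compound does not stand apart from the other two aryl variants, with a 1.3-fold lower number from compound 3 to compound 4 (0.11 log units; within the scatter) and a 1.3-fold lower number from compound 2 to compound 4 (0.11 log units; within the scatter), both within the scatter, so 4-chlorophenyl, 3-bromophenyl and 2-methylphenyl cannot be told apart in this read-out, and among the four compounds only the 4-fluorophenyl of compound 1 stands apart.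

Nothing available accounts for the size of the step from fluoro to chloro. The compounds shown leave open how a bromo, a methoxy, a nitrile or an amine on that same carbon would read, and whether chloro would give the same number elsewhere on the phenyl ring.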